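The source may hold more compounds than are shown below. What is called first, only, known or untested is meant among the compounds shown, and "the series" means these compounds.

Series notes. Compound 1 `N=C(N)c1cccc(CN2CC[C@H](NS(=O)(=O)c3ccc4ccncc4c3)C2=O)c1`, compound 2 `N=C(N)c1cccc(CN2CC[C@H](NS(=O)(=O)c3ccc4cccnc4c3)C2=O)c1` and compound 3 `N=C(N)c1cccc(CN2CC[C@H](NS(=O)(=O)c3ccc4ccc(N)nc4c3)C2=O)c1` share one core and differ only in the group on the sulfonyl sulfur. In an assay on isolated protein for binding affinity to serine protease 1 (Homo sapiens) (a higher number here means a weaker inhibitor, a lower number a stronger inhibitor), compound 1 gives > 2900 nM, which is a limit of the assay. In this assay compound 2 gives > 2900 nM, again a limit. Compound 3 gives > 2900 nM, a limit and not a number. The step that the two limits leave unreadable from compound 1 to compound 2 and the step that the two limits leave unreadable from compound 2 to compound 3 therefore cannot be sized, since all three values sit at the limit of > 2900 nM in this assay, at which 3 of the 3 values shown sit. Compound 4 `N=C(N)c1cccc(CN2CC[C@H](NS(=O)(=O)c3ccc4ccc(Cl)nc4c3)C2=O)c1` differs from compound 3 by chloro in place of amino on an aromatic carbon. Among the compounds with values here, no measured step offers a readable size, so the series gives no ground to expect a shift beyond the scatter. The expected step is a step that the limit leaves unreadable from compound 3 to compound 4. Compound 4 is thus estimated at 5000 nM, with a range from 2000 nM to 30000 nM.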

Compound 4, inhibition constant: > 2900 nM
Compound 4 gave a limit, no number; the forecaster's own chance of this, stated with the estimate: 80%; the middle value lies beyond the limit too.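

The steps from compound 2 and compound 3 to compound 4 cannot be read, since every value shown is a limit and not a number: the limit of > 2900 nM in this assay, at which 4 of the 4 values shown sit. The compounds shown leave open whether any group on the sulfonyl sulfur gives a readable value.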